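A few compounds are considered here, and "the series" means these few. Any claim that something is new, unique, unknown or untested is made for them only; others in the source may bear on it.

Within the data shown here, in a functional assay on MDA-MB-231 cells (Homo sapiens) for inhibition, read by MTT assay and WST assay, with a stated time of 72 h, tested at 10 uM (a lower number here means less inhibition of growth, a higher number more inhibition of growth at the concentration tested), compound 2 `O=C(Nc1ccc(Oc2ccc(-c3ncc[nH]3)cc2)cc1)Nc1ccc(F)c(C(F)(F)F)c1` gives 26.6%, the lower of the two numbers so far. Compound 1 `O=C(Nc1ccc(Cl)cc1)Nc1ccc(Oc2ccc(-c3ncc[nH]3)cc2)cc1` gives 47.6%. Among the measured compounds shown here, the one measured step, a number 21 percentage points lower from compound 1 to compound 2 (beyond the scatter), came with 4-fluoro-3-(trifluoromethyl)phenyl in place of 4-chlorophenyl on an amide-type nitrogen. Compound 3 `O=C(Nc1ccc(Oc2ccc(-c3ncc[nH]3)cc2)cc1)Nc1ccc(F)c(Cl)c1` differs from compound 2 by chloro in place of trifluoromethyl on an aromatic carbon, so that the aryl group becomes 3-chloro-4-fluorophenyl. For the measured compounds named here, no measured step exchanges a trifluoromethyl for a chloro directly; the step from compound 1 to compound 2 is the only one that bears on it, and it moved the whole aryl group at once. Compound 3 carries a chloro as compound 1 does but keeps the fluoro of compound 2, so a number between the two, a modest rise above compound 2, is expected. The expected step is a number 10.4 percentage points higher from compound 2 to compound 3 (beyond the scatter). For compound 3 in this assay the estimate is 37%, with a range of 22% to 52%.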

Compound 3, percent growth inhibition at one concentration: 4.2%
Compound 3: the middle estimate sits 32.8 percentage points above what was measured, outside the stated range (below it).
By their numbers in this assay, from the lowest: compound 3; then compound 2; then compound 1.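

In this assay, the group on the aromatic carbon ortho to the fluoro group counts on its own: with the fluoro group kept, chloro in place of trifluoromethyl came with a number 22.4 percentage points lower from compound 2 to compound 3 (beyond the scatter). A chloro on the aryl group therefore does not by itself hold the number of compound 1, and 3-chloro-4-fluorophenyl in place of 4-chlorophenyl came with a number 43.4 percentage points lower from compound 1 to compound 3 (beyond the scatter). Nothing on hand accounts for this order among the three compounds.

From the compounds shown here alone, compound 2 and compound 3 both carry the fluoro group, so its own share in these numbers stays open. Also open, going by these compounds, is how a methoxy group, an amine or a carboxylic acid on that same aromatic carbon would compare with chloro and trifluoromethyl.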